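The source may hold more compounds than are shown below. What is called first, only, known or untested is meant among the compounds shown, and "the series" means these compounds.

Within the data shown here, compound 2 `c1ccc(-c2ccno2)c(OCC2=NCCN2)c1` is the only compound of this small set with a numerical potency: in a functional assay for activation of Alpha-1B adrenergic receptor (Homo sapiens) (a higher number here means that more compound is needed for the effect, a lower number that less compound is needed), compound 2 gives 100 nM. Compound 1 `c1ccc(-c2ccccc2OCc2c[nH]cn2)cc1` carries a 1H-imidazol-4-yl group on a different core, and in this assay compound 1 returns only a limit, < 100000 nM; the limit is recorded as the limit of < 100000 nM in this assay, at which 1 of the 2 values shown sits. Among the measured compounds shown here, no step between two measured compounds is available, so the set offers nothing that directly anchors the change now under consideration.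

Compound 3 `c1ccc(-c2ccno2)c(OCc2c[nH]cn2)c1` differs from compound 2 by a group of 5 heavy atoms (3 carbon, 2 nitrogen; one five-membered aromatic ring with 2 hetero atoms) in place of a group of 5 heavy atoms (3 carbon, 2 nitrogen; one five-membered non-aromatic ring with 2 hetero atoms), on a saturated chain carbon bound to an oxygen on an aromatic ring. Since nothing measured ties this change to a shift in this assay, the expectation rests on judgement alone: a loss of potency is expected, with the step of a 30-fold higher number from compound 2 to compound 3 (1.48 log units; beyond the scatter) anticipated to lie beyond the usual scatter. Compound 3 is accordingly estimated at 3000 nM, with a likely range from 500 nM to 30000 nM, pending the actual measurement.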

Compound 3, half-maximal effective concentration: < 100000 nM
Compound 3 ended at the assay's limit (the forecaster's own chance of this, stated with the estimate: 15%); the middle value lies beyond the limit too.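

Compound 3, like compound 1, gives only a limit in this assay, so neither the step from compound 2 to compound 3 nor the step from compound 1 to compound 3 can be read: the limit of < 100000 nM in this assay, at which 2 of the 3 values shown sit.

The compounds shown leave open how large the change from the non-aromatic ring of compound 2 to 1H-imidazol-4-yl really is.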